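This account rests on a few compounds, and the source may have more. Where it says the series, first, only, none or still open, it means among the compounds named here.

Measured so far:
- compound 1 `C=CCOc1ccc(F)cc1C(=O)c1cccnc1`: 91000 nM
- compound 2 `O=C(c1cccnc1)c1cc(Cl)ccc1O`: 19500 nM

In a functional assay on IMR-32 cells (Homo sapiens) for cytotoxicity, read by sulforhodamine B assay, with a stated time of 48 h (on this read-out higher numbers stand for weaker inhibition and lower numbers for stronger inhibition), compound 1 gives 91000 nM, the higher of the two numbers and so the weaker inhibition. Compound 2 stands lower at 19500 nM, and this gap lies beyond the scatter. The two compounds differ in more than one place, so their gap isolates no single structural change.

The next compound is compound 3 `C=CCOc1ccccc1C(=O)c1cccnc1`, which keeps the allyloxy group of compound 1. The change is hydrogen in place of fluoro on an aromatic carbon, para to an allyloxy group. Among the compounds with values here, no measured pair shows this change, so the estimate has to start from compound 1 at 91000 nM. In this assay no step beyond the scatter is expected, with a slight lean towards a lower number. The expected step is a 1.3-fold lower number from compound 1 to compound 3 (0.11 log units; within the scatter). For compound 3 the expected value is 70000 nM, with an estimated range from 25000 nM to 200000 nM.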

Compound 3, half-maximal inhibitory concentration: 44000 nM
Compound 3: the middle estimate sits 1.6-fold (0.20 log units) above what was measured, and the stated range covers the measured number.
By their numbers in this assay, from the lowest: compound 2; then compound 3; then compound 1.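

In this assay, hydrogen in place of fluoro on an aromatic carbon, para to an allyloxy group, gives a 2.1-fold lower number from compound 1 to compound 3 (0.32 log units; beyond the scatter). Within the data shown here, this is the first single-place change that can be read, and it shows that the number at this position responds to the substituent, with the fluoro group of compound 1 not required for the lower number: compound 3 gives 44000 nM with hydrogen there. The step is modest and rests on one pair with the allyloxy group held constant, so it describes this pair only, and nothing measured here accounts for it.

Going by these compounds, what remains open is whether the position tolerates anything larger or different: an amine, a methoxy group or a carboxylic acid at the same aromatic carbon could move the number in either direction, and the direction seen with hydrogen and fluoro does not predict them. On these data alone, compound 2 differs from compound 3 in more than one place, so its printed value cannot yet be tied to any one change, and the effect of a longer chain in place of the allyloxy group also stays unknown.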